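Swapping the Chain-End Nitrile for an Alkyne

A few compounds are considered here, and "the series" means these few. Any claim that something is new, unique, unknown or untested is made for them only; others in the source may bear on it.

Of the compounds shown here, three sharing one core have been tested in an assay on isolated protein for binding affinity to leukotriene B4 receptor 1 (Homo sapiens), tested at 1 uM; a higher number here means more inhibition at the concentration tested (going by the name of the read-out), a lower number less inhibition. Compound 1 `CCCCCc1cc(C(C)=O)c(O)cc1OCCCCC#N` gives 14%. Compound 2 `CC(=O)c1cc(C=O)c(OCCCCC#N)cc1O` gives 3%. Compound 3 `C=CCc1cc(C(C)=O)c(O)cc1OCCCCC#N` gives 57%. Compound 3 stands highest of the three: the gap to its nearest neighbour is a number 43 percentage points higher from compound 1 to compound 3 (beyond the scatter), and to the furthest a number 54 percentage points higher from compound 2 to compound 3 (beyond the scatter); the step between the other two is a number 11 percentage points lower from compound 1 to compound 2 (beyond the scatter). Every one of these measured steps alters the group carried on an aromatic carbon of the core. Compound 4 `C#CCCCCOc1cc(O)c(C(C)=O)cc1CC=C` differs from compound 3 at a different place: ethynyl in place of cyano on a saturated chain carbon, four bonds along the chain from an oxygen on an aromatic ring. Within the data shown here, none of the measured steps touches that chain end, so no step bears directly on this change, and the large swings seen at the aromatic carbon give no guide to it. With nothing to support a shift in either direction, the expected step is a number 7 percentage points lower from compound 3 to compound 4 (within the scatter), no change beyond the scatter. Compound 4 is therefore estimated at 50%, within a range from 30% to 70%.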

Compound 4, a percentage reported as inhibition, at one concentration (the size of the read-out at that concentration, not a potency): 29%
Compound 4: middle estimate off by 21 percentage points, on the high side, outside the stated range (below it).
By their numbers in this assay, from the lowest: compound 2; then compound 1; then compound 4; then compound 3.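

The chain end turns out to be a position that matters: in this assay, ethynyl in place of cyano gives a number 28 percentage points lower from compound 3 to compound 4 (beyond the scatter), so this part of the molecule is not a neutral spot where the group can be exchanged freely. The two groups have the same heavy-atom count and each holds one triple bond, but the swap replaces nitrogen with carbon and removes the group's one hydrogen-bond acceptor. Still, nothing shown establishes which of these differences, if either, accounts for the lower number.

On these data alone, it remains open what a carboxylic acid or a primary amide at the chain end would give, and how a longer chain carrying the nitrile would compare. Also open, as far as these compounds go, is whether the same swap would shift the number similarly with pentyl in place of allyl on the aromatic carbon, as in compound 1.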